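The source may report more compounds than this note shows. Statements on the series, on what has been measured and on what is new or still open speak of the compounds shown alone.

Series notes, amide variation on the shared core.

Compound 1 `COc1ccc(-n2nc(C(N)=O)nc2-c2cc(OC)c(OC)c(OC)c2)cc1` carries an unsubstituted amide and in a functional assay on the whole organism for inhibition, with Rattus norvegicus as the target, read by paw edema, with stated times of 30 min and 3 h, at a dose of 0.28 mmol/kg by the oral route (a higher number here means more inhibition at the dose given (going by the name of the read-out), a lower number less inhibition), compound 1 gives 106%. Compound 2 `CCNC(=O)c1nc(-c2cc(OC)c(OC)c(OC)c2)n(-c2ccc(OC)cc2)n1` has ethyl on the amide-type nitrogen, and in this assay compound 2 gives 101%; the step of a number 5 percentage points lower from compound 1 to compound 2 (within the scatter) lies within the scatter. Compound 3 `COc1ccc(-n2nc(C(=O)Nc3ccccc3OC)nc2-c2cc(OC)c(OC)c(OC)c2)cc1` bears 2-methoxyphenyl on that nitrogen and in this assay compound 3 gives 44%, the lowest of the three numbers; the steps of a number 62 percentage points lower from compound 1 to compound 3 (beyond the scatter) and a number 57 percentage points lower from compound 2 to compound 3 (beyond the scatter) are both large and beyond the scatter, so an aryl group on this nitrogen goes with a markedly smaller read-out than hydrogen or ethyl.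

Compound 4 `COc1ccc(-n2nc(C(=O)Nc3cccc(F)c3)nc2-c2cc(OC)c(OC)c(OC)c2)cc1` is the next member. The change from compound 3 is 3-fluorophenyl in place of 2-methoxyphenyl on an amide-type nitrogen. Going by the values given here, no measured step exchanges one aryl group for another on this nitrogen; the two large steps only record the arrival of an aryl group, and they place compound 3 well under compounds 1 and 2. Among the compounds with values here, with that as the sole guide, compound 4 is expected to stay close to compound 3, the step of a number 6 percentage points higher from compound 3 to compound 4 (within the scatter) not expected to exceed the scatter. The estimate for compound 4 in this assay is 50%, with a range from 25% to 80%.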

Compound 4, a percentage reported as inhibition, in the whole organism at one dose (the size of the read-out at that dose, not a potency): 106%
Compound 4: middle estimate off by 56 percentage points, on the low side; measured number above the stated range.
By their numbers in this assay, from the lowest: compound 3; then compounds 2, 1 and 4 (each within the scatter of the next).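

In this assay an aryl group on the amide-type nitrogen does not by itself go with a smaller read-out, since 3-fluorophenyl in place of 2-methoxyphenyl gives a number 62 percentage points higher from compound 3 to compound 4 (beyond the scatter) and the step is as large as the ones that first set compound 3 apart. Set against the non-aryl amides, the 3-fluorophenyl amide shows a number 5 percentage points higher from compound 2 to compound 4 (within the scatter) and no change at the digits printed from compound 1 to compound 4 (within the scatter) so hydrogen, ethyl and 3-fluorophenyl are not separated on this nitrogen, and the low number belongs to the 2-methoxyphenyl amide alone among the four compounds. Nothing available bears on what lies behind the gap between the two aryl amides.

The step exchanges the substituent and its printed ring place together, so the compounds shown do not tell whether the methoxy group, its place, or both go with the low number of compound 3. On these data alone, how plain phenyl, a longer chain such as butyl, or a chain ending in an amine or a carboxylic acid would read on this nitrogen remains open.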